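The source may report more compounds than this note shows. Statements on the series, on what has been measured and on what is new or still open speak of the compounds shown alone.

Measured compounds and their values:

Compound 1, `O=[N+]([O-])c1ccc(-c2csc(Nc3n[nH]c(=S)n3-c3ccccc3)n2)cc1`: 300 mg/kg
Compound 2, `Cc1ccccc1-n1c(Nc2nc(-c3ccc([N+](=O)[O-])cc3)cs2)n[nH]c1=S`: 100 mg/kg
Compound 3, `Cc1ccc(-n2c(Nc3nc(-c4ccc(Br)cc4)cs3)n[nH]c2=S)cc1`: 300 mg/kg

Three compounds of this series were tested in a functional assay on the whole organism (strain Swiss albino) for inhibition, with Mus musculus as the target, with a stated time of 4 h; on this read-out lower numbers stand for an effect already at smaller amounts and higher numbers for an effect only at larger amounts of compound. In this assay compound 2 gives 100 mg/kg, while compound 1 gives 300 mg/kg and compound 3 gives 300 mg/kg. The pair of compound 2 and compound 1 differs in one place, (hydrogen in place of methyl on an aromatic carbon), and this change produced a 3.0-fold higher number from compound 2 to compound 1 (0.48 log units; beyond the scatter). Compound 3 and compound 1 stand level at the digits printed, and the difference between the cores of compound 3 and compound 2 is not broken down here.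

The unmeasured compound 4, `S=c1[nH]nc(Nc2nc(-c3ccc(Br)cc3)cs2)n1-c1ccccc1`, is related to compound 3 by hydrogen in place of methyl on an aromatic carbon. Among the compounds with values here, this is the same kind of change as the one from compound 2 to compound 1, but not the same: in the earlier pair the methyl sits ortho to a large group, whereas in compound 3 it sits para to a large group. Within the data shown here, only one measured instance of this kind of change exists, so the expectation rests on a single step. For compound 4 the estimated outcome is a 2.0-fold higher number from compound 3 to compound 4 (0.30 log units; within the scatter), a step of about the size seen earlier, because the earlier removal of the methyl gave a 3.0-fold higher number from compound 2 to compound 1 (0.48 log units; beyond the scatter). Compound 4 is therefore expected to give 600 mg/kg, with a range estimated from 300 mg/kg to 1000 mg/kg.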

Compound 4, minimum effective dose: 300 mg/kg
The estimate for compound 4 lay 2.0-fold (0.30 log units) above the measured number, within the range that was stated.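

In this assay, removing the methyl in the step 4-methylphenyl to phenyl gave no change at the digits printed from compound 3 to compound 4 (within the scatter), so the step seen on the nitro-bearing core did not carry over to the bromo-bearing core, and the two results differ: the same change on two cores in this assay, a 3.0-fold higher number (0.48 log units; beyond the scatter) from compound 2 to compound 1 and no change at the digits printed (within the scatter) from compound 3 to compound 4, 3.0-fold (0.48 log units) apart, beyond the scatter of two such steps With the methyl absent from both compounds, bromo in place of nitro gave no change at the digits printed from compound 1 to compound 4 (within the scatter), so this pair offers no sign that the group exchange alone moves the read-out. Within the data shown here, what the comparison does not show is why the methyl step differs, since it rests on only two pairs and these differ both in nitro or bromo and in where the methyl sits on the aromatic ring, leaving the two differences impossible to separate.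

The compounds shown leave open how the methyl step would behave with a methyl at the same place on both cores, or with an ethyl group or a longer chain in its stead. They also leave open what a methoxy group, an amine or a carboxylic acid in place of the nitro or bromo group would do to the dose needed in this whole-animal read-out.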